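The compounds below may be only part of what the source reports. "The series", "measured", "known", "first", "only" and "open" are said of these compounds alone.

Within the data shown here, compound 3 `COC(=O)/C=C/c1cccc(N(Cc2ccc(-c3cccc(Cl)c3)cc2)C(=O)C(C)C)c1` stands second highest of the three numbers so far in an assay on isolated protein with Bile acid receptor (Homo sapiens) as the target; on this read-out lower numbers stand for an effect already at smaller amounts and higher numbers for an effect only at larger amounts of compound: compound 3 gives 77 nM. Compound 1 `COC(=O)/C=C/c1cccc(N(Cc2ccc(-c3ccc(SC)cc3)cc2)C(=O)C(C)C)c1` gives 51 nM, and compound 2 `COC(=O)/C=C/c1cccc(N(Cc2ccc(-c3cccc(Cl)c3)cc2)C(=O)C2CCCCC2)c1` gives 94 nM. Both neighbouring steps, a 1.5-fold higher number from compound 1 to compound 3 (0.18 log units; within the scatter) and a 1.2-fold lower number from compound 2 to compound 3 (0.09 log units; within the scatter), lie within the scatter. Compound 4 `COC(=O)/C=C/c1cccc(N(Cc2ccc(/C=C/c3ccccc3)cc2)C(=O)C(C)C)c1` differs from compound 3 by 2-phenylethenyl in place of 3-chlorophenyl on an aromatic carbon. Of the measured steps only a 1.5-fold higher number from compound 1 to compound 3 (0.18 log units; within the scatter) concerns the same aromatic carbon, and it stayed within the scatter; the step of a 1.2-fold lower number from compound 2 to compound 3 (0.09 log units; within the scatter) alters the carbonyl side and does not bear on this change. No step beyond the scatter is therefore expected, a 1.0-fold higher number from compound 3 to compound 4 (0.02 log units; within the scatter). Compound 4 is estimated at 80 nM, with a range from 30 nM to 250 nM.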

Compound 4, half-maximal effective concentration: 65 nM
The estimate for compound 4 lay 1.2-fold (0.09 log units) above the measured number, and the stated range covers the measured number.
By their numbers in this assay, from the lowest: compounds 1, 4, 3 and 2 (each within the scatter of the next).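

The aromatic carbon para to a large group also accepts 2-phenylethenyl, which brings a double bond outside aromatic rings: a 1.2-fold lower number from compound 3 to compound 4 (0.07 log units; within the scatter) and a 1.3-fold higher number from compound 1 to compound 4 (0.11 log units; within the scatter) both stay within the scatter. Three different groups on this carbon now lie within the scatter of one another, so the change gives no separation among them. Nothing at hand gives a reason for this result.

Open remains how an amine on the terminal phenyl ring would read here. Also open, from the compounds shown here alone, is whether a longer chain in place of the ethenyl link would stay within the scatter.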